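The source may report more compounds than this note shows. Statements on the series, on what has been measured and on what is new or still open speak of the compounds shown alone.

Measured so far in an ADME assay on HEK293 cells (Homo sapiens) for cytotoxicity, read by MTT assay, with a stated time of 48 h; on this read-out higher numbers stand for weaker inhibition and lower numbers for stronger inhibition:
- compound 1 `Cc1nc(-c2ccc(Cl)cc2)sc1C(=O)CSc1nc(-c2ccc(Cl)c(Cl)c2)c(C#N)c(=O)[nH]1`: 46900 nM
- compound 3 `COc1ccc(-c2nc(C)c(C(=O)CSc3nc(-c4ccc(Cl)c(Cl)c4)c(C#N)c(=O)[nH]3)s2)cc1`: 45600 nM
- compound 2 `COc1ccc(-c2nc(SCC(=O)c3sc(-c4ccccc4)nc3C)nc(N)c2C#N)cc1`: "not determined" (no result reported)

Compound 1 stands with the highest of the two numbers, but compound 3 is a 1.0-fold lower number from compound 1 to compound 3 (0.01 log units; within the scatter), so the two are not separated on this read-out. Compound 2 contributes no number.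

Compound 4 `COc1cccc(-c2nc(SCC(=O)c3sc(-c4ccc(Cl)cc4)nc3C)[nH]c(=O)c2C#N)c1` is the next entry to be measured. It differs from compound 1 in this way: 3-methoxyphenyl in place of 3,4-dichlorophenyl on an aromatic carbon

For the measured compounds named here, only one measured step bears on it, and only loosely: the change from compound 1 to compound 3 swaps a chloro for a methoxy, though on a different aromatic carbon than the one altered here, and it gave a 1.0-fold lower number from compound 1 to compound 3 (0.01 log units; within the scatter). The change to compound 4 removes both chlorines of the 3,4-dichlorophenyl and brings in a 3-methoxyphenyl at the place described, so it is a larger alteration than the one already measured. Going by the values given here, still, the one available comparison shows that chloro-to-methoxy exchange left the cytotoxicity number unmoved, and no measured compound in this small set shows movement beyond the scatter. The expectation for compound 4 is therefore a step of a 1.0-fold lower number from compound 1 to compound 4 (0.01 log units; within the scatter), that is, none beyond the scatter.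

Estimated value for compound 4: 46000 nM, with a range from 20000 nM to 110000 nM.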

Compound 4, half-maximal inhibitory concentration: 77900 nM
Beside the measured number, compound 4's estimate is 1.7-fold (0.23 log units) below it; measured number inside the range.
By their numbers in this assay, from the lowest: compounds 3, 1 and 4 (each within the scatter of the next).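

This is the first change shown at the aromatic carbon next to the ring nitrogen and ortho to a cyano group, and in this assay replacing 3,4-dichlorophenyl with 3-methoxyphenyl gives a 1.7-fold higher number from compound 1 to compound 4 (0.22 log units; within the scatter) on this read-out. The entering and leaving groups have the same heavy-atom count, and the 3-methoxyphenyl carries a hydrogen-bond acceptor that the 3,4-dichlorophenyl lacks, yet the step does not separate the two compounds; the other single change from compound 1, a 1.0-fold lower number from compound 1 to compound 3 (0.01 log units; within the scatter), likewise stays within the scatter, so neither aryl change shown moves the number beyond it. No data shown here offer an account of this result.

From the compounds shown here alone, whether a phenyl carrying an amine or a carboxylic acid, or a morpholine in place of the aryl group, would move the number beyond the scatter at this position remains open. Also open, going by these compounds, is whether the two single changes from compound 1, combined in one compound, would stay within the scatter.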